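Moving the methyl: compound 2 to compound 3

This account rests on a few compounds, and the source may have more. Where it says the series, first, only, none or still open, it means among the compounds named here.

compound 1 `NC(=O)c1cc(Br)ccc1NC(=O)/C=C/c1ccccc1Br`, a limit: > 10000 nM
compound 2 `Cc1cccc(/C=C/C(=O)Nc2ccc(Br)cc2C(N)=O)c1`, a limit: > 10000 nM
compound 3 `Cc1ccc(/C=C/C(=O)Nc2ccc(Br)cc2C(N)=O)cc1`, not yet measured

In a functional assay on K562 cells (Homo sapiens) for inhibition, read by trypan blue exclusion, with a stated time of 48 h (on this read-out lower numbers stand for stronger inhibition and higher numbers for weaker inhibition), compound 2 gives only a limit, > 10000 nM. Among the measured compounds shown here, the series so far stands at the limit of > 10000 nM in this assay, at which 2 of the 2 values shown sit. Compound 3 keeps the same atoms, joined differently: 4-methylphenyl in place of 3-methylphenyl on a double-bonded chain carbon bound to a double-bonded chain carbon, with 4-methylphenyl in place of 3-methylphenyl on a double-bonded chain carbon bound to a double-bonded chain carbon. For the measured compounds named here, the one measured step is a step that the two limits leave unreadable from compound 1 to compound 2, and it supplies no size to carry over. With compound 2 held at the limit of > 10000 nM, no step beyond the scatter is expected in this assay, and no direction can be argued. The expected step is a number no higher from compound 2 to compound 3 (the limit leaves the size open). Another reading as a limit is expected to be the likelier outcome. Compound 3 is estimated at 10000 nM, with an expected range of 3000 nM to 20000 nM.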

Compound 3, half-maximal inhibitory concentration: > 10000 nM
Compound 3: only a limit was reported; the forecaster's own chance of this, stated with the estimate: 70%; the middle value sits exactly at the limit.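

Compound 1, compound 2 and compound 3 each give only a limit, so no step among them can be read: the limit of > 10000 nM in this assay, at which 3 of the 3 values shown sit.

The compounds shown leave open whether the group on the double-bonded chain carbon changes the read-out at all in this assay.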